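Aryl ether series: from 2,4,5-trichlorophenyl to 2-bromophenyl

This account rests on a few compounds, and the source may have more. Where it says the series, first, only, none or still open, it means among the compounds named here.

In a functional assay on A549 cells (Homo sapiens) for antiproliferative activity, read by MTT assay, with a stated time of 72 h (a higher number here means a weaker inhibitor, a lower number a stronger inhibitor), compound 3 `NC1=NC2(CCSCC2)N(OCCCOc2cc(Cl)c(Cl)cc2Cl)C(N)=N1` stands at > 100000 nM, which is a limit of the assay and not a number. Compound 1 `NC1=NC2(CCSCC2)N(OCCCOc2cccc(Cl)c2)C(N)=N1` gives 60 nM and compound 2 `NC1=NC2(CCSCC2)N(OCCCOc2ccc(Br)cc2)C(N)=N1` gives 740 nM. Compound 4 `NC1=NC2(CCSCC2)N(OCCCOc2ccccc2Br)C(N)=N1` changes the same group: 2-bromophenyl in place of 2,4,5-trichlorophenyl on an oxygen on a saturated carbon. Within the data shown here, three measured steps bear on this place: a 12-fold higher number from compound 1 to compound 2 (1.09 log units; beyond the scatter), an at least 1600-fold higher number from compound 1 to compound 3 (3.22 log units; beyond the scatter) and an at least 130-fold higher number from compound 2 to compound 3 (2.13 log units; beyond the scatter). Among the measured compounds shown here, no measured compound carries 2-bromophenyl, so compound 2 (740 nM) is the nearest guide, and a large step to a lower number is expected in this assay. The expected step is an at least 50-fold lower number from compound 3 to compound 4 (1.69 log units; beyond the scatter). For compound 4 the estimated value is 2000 nM, with an expected range of 150 nM to 30000 nM.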

Compound 4, half-maximal inhibitory concentration: 40 nM
For compound 4 the middle estimate is 50-fold (1.70 log units) above the measured one; measured number outside the range, below it.
By their numbers in this assay, from the lowest: compounds 4 and 1 (each within the scatter of the next); then compound 2. At a limit, above all of these: compound 3.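

In this assay, the place of a single bromine matters: 2-bromophenyl in place of 4-bromophenyl gives a 19-fold lower number from compound 2 to compound 4 (1.27 log units; beyond the scatter). 2-Bromophenyl and 3-chlorophenyl cannot be told apart, with a 1.5-fold lower number from compound 1 to compound 4 (0.18 log units; within the scatter). Compound 3 stands at a limit and not a number, so an at least 2500-fold lower number from compound 3 to compound 4 (3.39 log units; beyond the scatter) is only a bound: the limit of > 100000 nM in this assay, at which 1 of the 4 values shown sits.

Open, going by these compounds, is whether the loss with 2,4,5-trichlorophenyl follows the number of chlorines or their places. Also open, on these data alone, is how an amine or a carboxylic acid on the phenyl ring, or a longer chain before the oxygen, would read here.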